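A few compounds are considered here, and "the series" means these few. Any claim that something is new, unique, unknown or untested is made for them only; others in the source may bear on it.

The study concerns a shared core, seen in compound 1 `COc1ccc2nc(C)cc(OCC(=O)Nc3ccc(Cl)cc3)c2c1`, which carries an amide on its side chain. In a toxicity assay on HepG2 cells (Homo sapiens) for inhibition, read by CellTiter-Glo, with a stated time of 48 h (on this read-out higher numbers stand for weaker inhibition and lower numbers for stronger inhibition), compound 1 gives only a limit of the assay, > 100000 nM. Compound 2 `COc1ccc2nc(C)cc(OCC(=O)Nc3cc(C)nc(C)n3)c2c1` bears a 2,6-dimethylpyrimidin-4-yl in place of the 4-chlorophenyl on the amide-type nitrogen. In this assay compound 2 likewise gives only a limit, > 100000 nM. The step that the two limits leave unreadable from compound 1 to compound 2 therefore cannot be read, since both values sit at the same limit (the limit of > 100000 nM in this assay, at which 2 of the 2 values shown sit). Compound 2 thus stands without a number of its own, known only through that limit. Compound 3 `COc1ccc2nc(C)cc(OCC(=O)NC3CONC3=O)c2c1` alters the same amide-type nitrogen: a group of 6 heavy atoms (3 carbon, 1 nitrogen, 2 oxygen; one five-membered non-aromatic ring with 2 hetero atoms) in place of a group of 8 heavy atoms (6 carbon, 2 nitrogen; one six-membered aromatic ring with 2 hetero atoms), on an amide-type nitrogen. For the measured compounds named here, the one measured step touches this change only by sharing its place, and its size is unreadable, so no direction can be drawn from it. The expectation is that compound 3 stays at the limit, so that a step of a number no higher from compound 2 to compound 3 (the limit leaves the size open) in this assay is expected. For compound 3 the estimate is 100000 nM, with an expected range from 30000 nM to 300000 nM.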

Compound 3, half-maximal inhibitory concentration: > 100000 nM
Compound 3 was reported as a limit; the forecaster's own chance of this, stated with the estimate: 85%; the middle value sits exactly at the limit.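

For the compounds shown here, compound 3 also gives only a limit in this assay, so no step among compound 1, compound 2 and compound 3 can be read: the limit of > 100000 nM in this assay, at which 3 of the 3 values shown sit. The compounds shown leave open whether any change on the amide-type nitrogen alters this read-out, as none of the three has a number of its own.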